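Swapping fluoro for trifluoromethyl on compound 3

A few compounds are considered here, and "the series" means these few. Any claim that something is new, unique, unknown or untested is made for them only; others in the source may bear on it.

Compound 1 `O=C(/C=C/c1cccc(F)c1)c1ccc(-n2ccnc2)cc1`: > 10000 nM
Compound 2 `O=C(/C=C/c1ccc(Br)cc1)c1ccc(-n2ccnc2)cc1`: 320 nM
Compound 3 `O=C(/C=C/c1ccc(F)cc1)c1ccc(-n2ccnc2)cc1`: > 10000 nM

Three compounds share one core and differ only in the aryl group at the end of the double-bonded chain. In an assay on isolated protein for inhibition of Amine oxidase [flavin-containing] B (Homo sapiens) (on this read-out lower numbers stand for stronger inhibition and higher numbers for weaker inhibition), compound 3 gives > 10000 nM, which is a limit of the assay and not a number. Compound 1 likewise gives > 10000 nM, also a limit. Compound 2 gives 320 nM. The step of an at least 31-fold higher number from compound 2 to compound 3 (1.49 log units; beyond the scatter) therefore stands out, as does an at least 31-fold lower number from compound 1 to compound 2 (1.49 log units; beyond the scatter); both set the bromo analogue well apart from the two fluoro compounds, which sit at the limit of > 10000 nM in this assay, at which 2 of the 3 values shown sit. Compound 4 `O=C(/C=C/c1ccc(C(F)(F)F)cc1)c1ccc(-n2ccnc2)cc1` is not yet measured; it differs from compound 3 by trifluoromethyl in place of fluoro on an aromatic carbon. Because compound 2, which carries bromo, gives 320 nM, the trifluoromethyl group is expected to bring a lower number, so compound 4 is estimated at 800 nM with a range of 150 nM to 6000 nM. The expected step is an at least 12-fold lower number from compound 3 to compound 4 (1.09 log units; beyond the scatter).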

Compound 4, half-maximal inhibitory concentration: > 10000 nM
Compound 4: only a limit was reported; the forecaster's own chance of this, stated with the estimate: 20%; middle value at least 12-fold (1.09 log units) away from the limit.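

Trifluoromethyl on this aromatic carbon does not reproduce the result with bromo, with an at least 31-fold higher number from compound 2 to compound 4 (1.49 log units; beyond the scatter). Among compounds 2, 3 and 4, which differ only at this place, bromo alone gives a reading that is a number. In this assay the reading for compound 4 is only a limit, so steps between such limits cannot be read: the limit of > 10000 nM in this assay, at which 3 of the 4 values shown sit.

As far as these compounds go, it stays open whether chloro, iodo or methoxy at this place would give a readable value. From the compounds shown here alone, how far compounds 1, 3 and 4 lie beyond their limits also stays open.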